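Aryl swap on the ring nitrogen: from compound 3 to compound 4

The source may report more compounds than this note shows. Statements on the series, on what has been measured and on what is new or still open speak of the compounds shown alone.

Compound 3 `Nc1scc(CN2CCN(c3ccc(C(F)(F)F)cc3)CC2)c1C(=O)c1cccc(C(F)(F)F)c1` gives -11% in a functional assay on CHO cells with adenosine receptor A1 (Homo sapiens) as the target, read by cAMP accumulation and immunoassay, with a stated time of 6 min, tested at 0.1 uM (on this read-out higher numbers stand for a weaker effect at the one concentration tested and lower numbers for a stronger effect), the second highest of the three numbers; compound 1 `Nc1scc(CN2CCN(c3cccc(Cl)c3Cl)CC2)c1C(=O)c1ccc(Cl)cc1` gives 3.2% and compound 2 `Nc1scc(CN2CCN(c3cccc(C(F)(F)F)c3)CC2)c1C(=O)c1ccc(Cl)cc1` gives -30%. Compound 4 `Nc1scc(CN2CCN(c3cccc(F)c3)CC2)c1C(=O)c1cccc(C(F)(F)F)c1` is not yet measured; it differs from compound 3 by 3-fluorophenyl in place of 4-(trifluoromethyl)phenyl on an amine nitrogen in a ring. Within the data shown here, the only step measured at the same place is a number 33.2 percentage points lower from compound 1 to compound 2 (beyond the scatter), which shows that exchanging the aryl group on that ring nitrogen can shift the read-out well beyond the scatter, though with different groups. A step beyond the scatter is therefore plausible in either direction, and the estimated step is a number 4 percentage points lower from compound 3 to compound 4 (within the scatter). Compound 4 is expected to give -15%, within -45% to 15%.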

Compound 4, a percentage reported as activity, at one concentration (the size of the read-out at that concentration, not a potency): -12%
Estimate against measurement, compound 4: 3 percentage points below; the range from low to high includes it.
By their numbers in this assay, from the lowest: compound 2; then compounds 4 and 3 (each within the scatter of the next); then compound 1.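

With the rest of the molecule unchanged, 3-fluorophenyl in place of 4-(trifluoromethyl)phenyl on the ring nitrogen gives a number 1 percentage points lower from compound 3 to compound 4 (within the scatter) in this assay. Unlike the earlier step at this position, this shows that exchanging the aryl group there need not shift the read-out beyond the scatter. No evidence is available to explain this result. As far as these compounds go, it remains open whether a methoxyphenyl or an unsubstituted phenyl on that nitrogen would give a larger step, and whether this exchange would behave alike on the core of compound 1.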